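A fluorophenyl swap from compound 2 to compound 4

A few compounds are considered here, and "the series" means these few. Any claim that something is new, unique, unknown or untested is made for them only; others in the source may bear on it.

Measured so far in a functional assay on HCT-116 cells (Homo sapiens) for antiproliferative activity, read by MTT assay, with a stated time of 24 h (a lower number here means a stronger inhibitor, a higher number a weaker inhibitor), are these compounds
Compound 1 `COc1ccc(C(=O)/C=C/c2cc(OC)c(OC)c(OC)c2)c2c1C=CC(C)(C)O2` gives 7650 nM
Compound 2 `COc1ccc(/C=C/C(=O)c2ccc(OC)c3c2OC(C)(C)C=C3)c(F)c1` gives a limit (> 10000 nM)
Compound 3 `COc1cc(OC)c(OC)cc1/C=C/C(=O)c1ccc(OC)c2c1OC(C)(C)C=C2` gives a limit (> 10000 nM)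

Compound 2 has no number in this assay and stands only at a limit (> 10000 nM). Compound 3 shares that position, so the picture is the limit of > 10000 nM in this assay, at which 2 of the 3 values shown sit (the only exact figure belongs to the third compound). In compound 1 that figure is 7650 nM and it gives the sole numerical anchor.

Compound 4 `COc1ccc(C(=O)/C=C/c2cccc(F)c2)c2c1C=CC(C)(C)O2` has not yet been measured. It carries 3-fluorophenyl in place of 2-fluoro-4-methoxyphenyl on a double-bonded chain carbon bound to a double-bonded chain carbon. Going by the values given here, no step between measured compounds shows what such a change does. The estimated a number no higher from compound 2 to compound 4 (the limit leaves the size open) is expected to stay within the scatter, with no clear direction. For compound 4 the estimated value is 10000 nM (expected range 4500 nM to 25000 nM).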

Compound 4, half-maximal inhibitory concentration: > 10000 nM
Compound 4 ended at the assay's limit; the forecaster's own chance of this, stated with the estimate: 55%; the middle value lies on the limit itself.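

In this assay, compound 2 and compound 4 both stand at a limit and not at a number, so no step can be read between them: the limit of > 10000 nM in this assay, at which 3 of the 4 values shown sit.

The compounds shown leave open what 3-fluorophenyl in place of 2-fluoro-4-methoxyphenyl does to the antiproliferative activity in this assay.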